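One number among limits before a group swap

The source may hold more compounds than are shown below. What is called first, only, known or untested is meant among the compounds shown, and "the series" means these compounds.

In a functional assay on MCF7 cells (Homo sapiens) for antiproliferative activity, read by CellTiter-Glo, with a stated time of 5 days (a higher number here means a weaker inhibitor, a lower number a stronger inhibitor), compound 1 (`CC/C(=C(/c1ccc(/C=C/C(=O)O)cc1)c1ccn2ccnc2c1)c1ccccc1`) gives > 500 nM as its result, which is a limit and not a number. Compound 2 (`CC/C(=C(/c1ccc(/C=C/C(=O)O)cc1)c1ccc2ncsc2c1)c1ccccc1`) gives > 500 nM as its result, again a limit. For the measured compounds named here, compound 3 (`CC/C(=C(/c1ccc(/C=C/C(=O)O)cc1)c1ccc(-c2cc[nH]n2)cc1)c1ccccc1`) gives 440 nM as the only true number so far. Compound 4 (`CC/C(=C(/c1ccc(/C=C/C(=O)O)cc1)c1ccc(N2CCN(C)CC2)cc1)c1ccccc1`) carries 4-methylpiperazin-1-yl in place of 1H-pyrazol-3-yl on an aromatic carbon. Going by the values given here, the one measured step (a step that the two limits leave unreadable from compound 1 to compound 2) offers no size to carry over. The expected step (a 1.3-fold higher number from compound 3 to compound 4 (0.10 log units; within the scatter)) in this assay therefore stays within the usual scatter, with no firm direction. For compound 4 the estimated value is 550 nM with an expected range from 150 nM to 2000 nM as a rough guess.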

Compound 4, half-maximal inhibitory concentration: 220 nM
Compound 4: middle estimate off by 2.5-fold (0.40 log units), on the high side; the measured number falls inside the stated range.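

For the compounds shown here, putting 4-methylpiperazin-1-yl in place of 1H-pyrazol-3-yl gives a 2.0-fold lower number from compound 3 to compound 4 (0.30 log units; within the scatter) in this assay and is the first readable step. On this aromatic carbon, then, a non-aromatic ring and an aromatic ring cannot be told apart by this result, although the two groups differ in hydrogen-bond donors and acceptors. The step between compounds 1 and 2 could not show this, because each of their results is a limit and not a number: the limit of > 500 nM in this assay, at which 2 of the 4 values shown sit.

The compounds shown leave open whether other groups at this place, such as a simple amine, a carboxylic acid or a morpholine ring, would give a step beyond the scatter.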